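Dropping the benzyl from a sulfonamide nitrogen

The compounds below may be only part of what the source reports. "The series", "measured", "known", "first", "only" and "open" are said of these compounds alone.

Of the compounds shown here, three sharing one core have been measured in a functional assay (aorta) for antagonist activity, with Oryctolagus cuniculus as the target; on this read-out lower numbers stand for stronger inhibition and higher numbers for weaker inhibition. Compound 1 `CCCCc1ccc(CN(Cc2ccccc2)S(=O)(=O)c2ccccc2)c(=O)n1Cc1ccc(-c2ccccc2-c2nn[nH]n2)cc1` gives 20 nM. Compound 2 `CCCCc1ccc(CNC(=O)NC2CCCCC2)c(=O)n1Cc1ccc(-c2ccccc2-c2nn[nH]n2)cc1` gives 90 nM, and compound 3 `CCCCc1ccc(CNC(=O)OC(C)(C)C)c(=O)n1Cc1ccc(-c2ccccc2-c2nn[nH]n2)cc1` gives 10 nM. Among these three numbers compound 1 stands second highest: its number sits within the scatter of compound 3, while compound 2 shows a clearly higher number than compound 1.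

Compound 4 `CCCCc1ccc(CNS(=O)(=O)c2ccccc2)c(=O)n1Cc1ccc(-c2ccccc2-c2nn[nH]n2)cc1` has not yet been measured. It differs from compound 1 in one place: hydrogen in place of benzyl on a sulfonamide nitrogen. The sulfonamide itself stays, only the benzyl group on its nitrogen is gone.

For the measured compounds named here, the single measured step, a 9.0-fold lower number from compound 2 to compound 3 (0.95 log units; beyond the scatter), concerns a different part of the molecule, where a carbonyl carbon carries either a cyclohexylamino or a tert-butoxy group. Going by the values given here, no measured pair shows what removing a benzyl from the sulfonamide nitrogen does, so there is no step that bears directly on this change. With no direct guide, the expectation for compound 4 is a moderate rise in number, the step of a 3.0-fold higher number from compound 1 to compound 4 (0.48 log units; beyond the scatter), with a wide band of uncertainty. Compound 4 is therefore estimated at 60 nM, expected to fall between 15 nM and 300 nM in this assay.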

Compound 4, half-maximal inhibitory concentration: 7 nM
Estimate against measurement, compound 4: 8.6-fold (0.93 log units) above; the whole stated range lies above it.
By their numbers in this assay, from the lowest: compounds 4, 3 and 1 (each within the scatter of the next, the first and the last beyond it); then compound 2.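

The benzyl on the sulfonamide nitrogen turns out not to be required in this assay: with hydrogen in its place, inhibition becomes stronger (a 2.9-fold lower number from compound 1 to compound 4 (0.46 log units; beyond the scatter)), so this nitrogen works well with no carbon substituent at all. The simple phenylsulfonyl group on the amine nitrogen also stands level with tert-butoxycarbonyl, since this difference lies within the scatter (a 1.4-fold lower number from compound 3 to compound 4 (0.15 log units; within the scatter)), and it gives much stronger inhibition than cyclohexylcarbamoyl (a 13-fold lower number from compound 2 to compound 4 (1.11 log units; beyond the scatter)), so quite different groups at this place can reach similar numbers. No measurement gives a reason for any of these differences.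

A methyl or an ethyl on the sulfonamide nitrogen would show whether any carbon group there raises the number or whether the effect belongs to benzyl alone. From the compounds shown here alone, the phenyl on the sulfonyl sulfur also remains untested as a variable, so it is unknown whether a methyl in its place would keep the number of compound 4 (7 nM).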